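Adding a fluoro to compound 3

The source may report more compounds than this note shows. Statements on the series, on what has been measured and on what is new or still open speak of the compounds shown alone.

Compound 1 `Cn1ccc2c(Oc3ccc(NC(=O)c4cc5cccnc5n(-c5ccccc5)c4=O)cc3)ncnc21` gives 59800 nM
Compound 2 `Cn1ccc2c(Oc3ccc(NC(=O)c4cc5cccnc5n(-c5ccc(Br)cc5)c4=O)cc3)ncnc21` gives 43800 nM
Compound 3 `Cn1ccc2c(Oc3ccc(NC(=O)c4cc5cccnc5n(-c5ccccc5)c4=O)cc3F)ncnc21` gives 51800 nM

All three numbers come from a functional assay on HeLa cells (Homo sapiens) for cytotoxicity, read by MTT assay, with a stated time of 72 h; a higher number here means a weaker inhibitor, a lower number a stronger inhibitor. Compound 3 with 51800 nM lies within the usual scatter of both compound 1 and compound 2, so these measurements do not separate it from either of them.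

Compound 4 `Cn1ccc2c(Oc3ccc(NC(=O)c4cc5cccnc5n(-c5ccc(F)cc5)c4=O)cc3F)ncnc21` has not been measured yet. It turns the phenyl of compound 3 into 4-fluorophenyl: fluoro in place of hydrogen on an aromatic carbon in other words fluoro in place of hydrogen on an aromatic carbon, para to a large group.

Going by the values given here, two measured steps bear on this change. Bromo in place of hydrogen on an aromatic carbon gave a 1.4-fold lower number from compound 1 to compound 2 (0.14 log units; within the scatter) and fluoro in place of hydrogen on an aromatic carbon gave a 1.2-fold lower number from compound 1 to compound 3 (0.06 log units; within the scatter) so both were small enough to be lost in the noise of repeat measurements. On that evidence no change beyond the scatter is expected in this assay and any drift would most likely be toward a slightly lower number. The expected size of the change is a 1.2-fold lower number from compound 3 to compound 4 (0.06 log units; within the scatter) and nothing larger is anticipated. Compound 4 is estimated in this assay at 45000 nM with 26000 nM to 75000 nM as its expected range.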

Compound 4, half-maximal inhibitory concentration: 4250 nM
Compound 4: middle estimate off by 11-fold (1.02 log units), on the high side; measured number below the stated range.
By their numbers in this assay, from the lowest: compound 4; then compounds 2, 3 and 1 (each within the scatter of the next).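

In this assay the change from phenyl to 4-fluorophenyl gave a 12-fold lower number from compound 3 to compound 4 (1.09 log units; beyond the scatter) and thereby moved the number well beyond the scatter, which neither earlier step did, so a single fluoro at this place can matter a great deal in this series. The same place had earlier taken a bromo with only a 1.4-fold lower number from compound 1 to compound 2 (0.14 log units; within the scatter) as the result, but that step began from compound 1, which lacks the fluoro already carried by compound 3, so the two steps differ both in the halogen that enters and in the compound it enters. No measurement on hand explains why this one atom made so large a difference.

The compounds shown leave open whether the large step depends on the fluoro already present in compound 3, or whether 4-fluorophenyl would give a similar step on compound 1 as well. They also leave open whether a chloro, a methoxy or an amine at this same place would behave like the fluoro or like the bromo, and so whether the effect is particular to fluoro.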